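The source may hold more compounds than are shown below. What is called first, only, known or untested is meant among the compounds shown, and "the series" means these compounds.

Measured compounds in an assay on isolated protein for agonist activity at Bile acid receptor (Homo sapiens), read by AlphaScreen, with a stated time of 30 min; a lower number here means that less compound is needed, a higher number that more compound is needed for the effect:
compound 1 `Cc1ccccc1-n1nc(C)c2c1NC(=O)[C@H](C)S[C@@H]2c1ccc(-c2ccoc2)cc1`: 3500 nM
compound 2 `Cc1ccc(-n2nc(C)c3c2NC(=O)[C@H](C)S[C@@H]3c2ccc(Oc3ccccc3)cc2)cc1`: 3400 nM

Compound 1 holds the highest of the two numbers in this assay, but compound 2 sits so close to it that the two values cannot be told apart, and no order between them is claimed. For the measured compounds named here, no pair of measured compounds differs in a single place, so no measured step is available to guide a prediction.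

Compound 3 `COC(=O)c1cccc(-c2ccc([C@H]3S[C@@H](C)C(=O)Nc4c3c(C)nn4-c3ccccc3C)cc2)c1` is the unmeasured member of the set. It arises from compound 1 by the change (3-(methoxycarbonyl)phenyl in place of furan-3-yl on an aromatic carbon). The group that enters carries more heavy atoms and one more hydrogen-bond acceptor than the group that leaves, while the core of compound 1 and the rest of the molecule stay as they are.

Nothing in the two measured values speaks for or against this particular exchange, so the expected step from compound 1 to compound 3 is a 1.3-fold lower number from compound 1 to compound 3 (0.10 log units; within the scatter), which is not expected to lie clearly beyond the scatter. For compound 3 in this assay the estimated value is 2800 nM, with a range from 800 nM to 9000 nM.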

Compound 3, half-maximal effective concentration: "not active" (no number reported)
Nothing numeric was reported for compound 3; there is nothing to compare the estimate with.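

In this assay, for the compounds shown here, compound 3 is reported as "not active" with no number, and no step from compound 1 to compound 3 can be read. No available evidence bears on this result. The compounds shown leave open how large the difference between compound 1 and compound 3 is in this assay.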